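This account rests on a few compounds, and the source may have more. Where it says the series, first, only, none or still open, it means among the compounds named here.

Compounds measured in an ADME assay on HEK293 cells (Homo sapiens) for cytotoxicity, read by MTT assay, with a stated time of 48 h; a lower number here means a stronger inhibitor, a higher number a weaker inhibitor:
compound 1 `Oc1ccc(N2CCN(CC(O)COc3cccc4ccccc34)CC2)c(O)c1` — > 50000 nM, a limit of this assay, not a number
compound 2 `COc1cc(O)ccc1N1CCN(CC(O)COc2cccc3ccccc23)CC1` — > 50000 nM, likewise a limit of this assay

Compound 2 therefore stands at the assay limit; both values sit there (the limit of > 50000 nM in this assay, at which 2 of the 2 values shown sit). Going by the values given here, the one measured step, a step that the two limits leave unreadable from compound 1 to compound 2, methyl in place of hydrogen on an oxygen on an aromatic ring, cannot be read from the two limits. Compound 3 `COc1cc(O)ccc1N1CCN(CC(O)COc2ccc(O)c3ccccc23)CC1` differs from compound 2 by hydroxy in place of hydrogen on an aromatic carbon. Among the compounds with values here, no measured step bears on this change, so in this assay no step beyond the scatter is anticipated, and a further limit is the most likely outcome. Compound 3 is expected at about 70000 nM, range 20000 nM to 250000 nM, an expected step that the limit leaves unreadable from compound 2 to compound 3.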

Compound 3, half-maximal inhibitory concentration: > 50000 nM
Compound 3: no number, only a limit; the forecaster's own chance of this, stated with the estimate: 85%; the middle value lies beyond the limit too.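

Compound 2 and compound 3 both give only a limit, so no step can be read between them: the limit of > 50000 nM in this assay, at which 3 of the 3 values shown sit.

The compounds shown leave open whether any change to the shared core would give a readable number in this assay.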